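This account rests on a few compounds, and the source may have more. Where it says the series, first, only, none or still open, it means among the compounds named here.

Of the compounds shown here, three sharing one core have been measured in an assay on cells with melanin-concentrating hormone receptor 1 (Homo sapiens) as the target, read by radioligand binding; on this read-out lower numbers stand for stronger inhibition and higher numbers for weaker inhibition. Compound 1 `CC1CCCCC1Oc1cccc2ccc(N)nc12` gives 32 nM, compound 2 `CCOCC(C)Oc1cccc2ccc(N)nc12` gives 1070 nM, and compound 3 `CC(COC(C)(C)C)Oc1cccc2ccc(N)nc12` gives 306 nM. Compound 2 stands highest of the three, with compound 3 nearest and compound 1 furthest. Compound 4 `CC#CCCOc1cccc2ccc(N)nc12` differs from compound 2 in one place: a group of 5 heavy atoms (5 carbon; no ring) in place of a group of 6 heavy atoms (5 carbon, 1 oxygen; no ring), on an oxygen on an aromatic ring. Within the data shown here, the only measured step on this side chain is a 3.5-fold lower number from compound 2 to compound 3 (0.54 log units; beyond the scatter), which shows that reshaping the group on that oxygen can move the number beyond the scatter. In addition, compound 1 gives 32 nM while compound 2 gives 1070 nM, so other groups at this position have reached far lower numbers. A modest fall in this assay is therefore expected, a 4.3-fold lower number from compound 2 to compound 4 (0.63 log units; beyond the scatter). Compound 4 is estimated at 250 nM, within a range of 70 nM to 900 nM.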

Compound 4, half-maximal inhibitory concentration: > 2000 nM
Compound 4: only a limit was reported; the forecaster's own chance of this, stated with the estimate: 3%; at least 8.0-fold (0.90 log units) between middle value and limit.
By their numbers in this assay, from the lowest: compound 1; then compound 3; then compound 2. At a limit, above all of these: compound 4.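

In this assay compound 4 is recorded only as a limit, > 2000 nM. The step is an at least 1.8-fold higher number from compound 2 to compound 4 (0.27 log units; that floor lies within the scatter), so a real rise over compound 2 is not established. Even so, this position does not reward every reshaping of the group on the oxygen: pent-3-yn-1-yl shows none of the fall seen with the other groups.

The compounds shown leave open whether the triple bond or the loss of the chain's oxygen matters here, and a saturated pentyl chain would separate the two. As far as these compounds go, how an amine in the chain would read also stays open.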